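The source may report more compounds than this note shows. Statements on the series, on what has been measured and on what is new or still open speak of the compounds shown alone.

In a functional assay on the whole organism (strain albino) for inhibition, with Rattus norvegicus as the target, read by paw edema, with stated times of 30 min and 1 h, at a dose of 100 mg/kg by the oral route (a lower number here means less inhibition, a higher number more inhibition at the dose given (going by the name of the read-out)), compound 1 `Nc1ccc(C(=O)/C=C/c2ccc(Cl)cc2)cc1` gives 41%, the highest of the three numbers recorded so far. Compound 2 `COc1ccc(/C=C/C(=O)c2ccc(NC(=O)CBr)cc2)cc1` gives 37%, which lies within the scatter of compound 1, while compound 3 `O=C(CBr)Nc1ccc(C(=O)/C=C/c2ccco2)cc1` gives 30%, beyond the scatter below compound 1. Compound 4 `O=C(CO[N+](=O)[O-])Nc1ccc(C(=O)/C=C/c2ccc(Cl)cc2)cc1` has not yet been measured; it differs from compound 1 by ((nitrooxy)methyl)carbonyl in place of hydrogen on a nitrogen on an aromatic ring. For the measured compounds named here, no measured pair shows this change alone, and compounds 2 and 3 differ from compound 1 in more than this one place, so their values give no isolated step for it. The expected step of a number 3 percentage points lower from compound 1 to compound 4 (within the scatter) is small, within the scatter, with no direction favoured. The estimate for compound 4 is 38%, in a range of 26% to 50%.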

Compound 4, a percentage reported as inhibition, in the whole organism at one dose (the size of the read-out at that dose, not a potency): 42%
Compound 4: the middle estimate sits 4 percentage points below what was measured, and the stated range covers the measured number.
By their numbers in this assay, from the lowest: compounds 3, 2, 1 and 4 (each within the scatter of the next, the first and the last beyond it).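

In this assay, for the compounds shown here, the step at this position can now be read in isolation for the first time: ((nitrooxy)methyl)carbonyl in place of hydrogen on a nitrogen on an aromatic ring gives a number 1 percentage points higher from compound 1 to compound 4 (within the scatter). The free amino group of compound 1 can therefore carry this substituent with no difference outside the scatter at the single dose tested. Nothing available explains this result.

On these data alone, it remains open whether a plain acetyl group or a longer chain on the same nitrogen would read the same. As far as these compounds go, whether this step carries over to a different core also remains open.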